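Methyl in place of hydrogen on the nitrogen of compound 3

The source may report more compounds than this note shows. Statements on the series, on what has been measured and on what is new or still open speak of the compounds shown alone.

Compound 1 `CC1(C)CCC(C)(C)c2cc(C3=NOC(c4ccc(C(=O)O)cc4)C3)ccc21`, compound 2 `CC1(C)CCC(C)(C)c2cc(C3CC(c4ccc(C(=O)O)cc4)=NO3)ccc21` and compound 3 `CC1(C)CCC(C)(C)c2cc(CNc3ccc(C(=O)O)cc3)ccc21` share one core and differ only in the linker to the second ring. In a functional assay on HL-60 cells (Homo sapiens) for inhibition (a higher number here means a weaker inhibitor, a lower number a stronger inhibitor), compound 1 gives 68000 nM. In this assay compound 2 gives 75000 nM, and compound 3 gives 40000 nM. Compound 3 carries the lowest of the three numbers, but both gaps lie within the scatter, so no order among the three is claimed.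

Compound 4 `CN(Cc1ccc2c(c1)C(C)(C)CCC2(C)C)c1ccc(C(=O)O)cc1` differs from compound 3 by methyl in place of hydrogen on a nitrogen on an aromatic ring. Going by the values given here, no measured pair shows what such a change does in this assay, so a step of no more than the scatter in either direction is expected. The step of a 1.1-fold lower number from compound 3 to compound 4 (0.06 log units; within the scatter) is expected to stay within the scatter. Compound 4 is accordingly estimated at 35000 nM, with a range from 12000 nM to 100000 nM.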

Compound 4, half-maximal inhibitory concentration: 58000 nM
Compound 4: the middle estimate sits 1.7-fold (0.22 log units) below what was measured; the range from low to high includes it.
By their numbers in this assay, from the lowest: compounds 3, 4, 1 and 2 (each within the scatter of the next).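

In this assay, going by these compounds alone, the first pair that isolates a change on this nitrogen gives a 1.5-fold higher number from compound 3 to compound 4 (0.16 log units; within the scatter) and so the hydrogen on that nitrogen can be replaced by methyl without a step beyond the scatter. Compound 3 and compound 4 therefore cannot be told apart here, and nothing available explains the result or bears on it.

On these data alone, whether an ethyl group, a longer chain or an acetyl group on this nitrogen would also stay within the scatter remains open.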